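This account rests on a few compounds, and the source may have more. Where it says the series, first, only, none or still open, it means among the compounds named here.

For the measured compounds named here, in a functional assay on Jurkat cells (Homo sapiens) for antiproliferative activity, read by MTT assay, with a stated time of 72 h (a higher number here means a weaker inhibitor, a lower number a stronger inhibitor), compound 1 `COc1cc(-n2ncnc2-c2ccc(C)cc2)cc(OC)c1OC` gives 300 nM, the only exact number available. Compound 2 `COc1cc(-c2ncnn2-c2ccc(N)cc2)cc(OC)c1OC` reads > 10000 nM, which is a limit of the assay. Compound 3 `COc1cc(-c2ncnn2-c2ccc(Cl)cc2)cc(OC)c1OC` reads > 10000 nM, also a limit. Compound 4 `CCOc1ccc(-c2ncnn2-c2cc(OC)c(OC)c(OC)c2)cc1` keeps the core of compound 1 and changes one group: ethoxy in place of methyl on an aromatic carbon. This puts ethoxy in place of methyl on an aromatic carbon, para to a large group. Going by the values given here, the only measured step is a step that the two limits leave unreadable from compound 2 to compound 3, so it offers no size to carry over to this change. No shift beyond the scatter is therefore expected in this assay, in either direction. The estimated step is a 1.5-fold lower number from compound 1 to compound 4 (0.18 log units; within the scatter). For compound 4 the estimated value is 200 nM. The expected range for compound 4 runs from 30 nM to 1500 nM.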

Compound 4, half-maximal inhibitory concentration: 5 nM
The estimate for compound 4 lay 40-fold (1.60 log units) above the measured number; the whole stated range lies above it.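

In this assay, ethoxy in place of methyl on an aromatic carbon, para to a large group, gives a 60-fold lower number from compound 1 to compound 4 (1.78 log units; beyond the scatter). This position therefore answers strongly to the group it carries, and a group of three heavy atoms is not merely tolerated there. The earlier compounds could not show this, since compound 2 and compound 3 both read as limits, which leaves their step unreadable: the limit of > 10000 nM in this assay, at which 2 of the 4 values shown sit.

Going by these compounds, whether the oxygen or the chain length matters more stays open. Methoxy and a propyl chain at this position would help separate the two.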